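Carbonyl to sulfonyl on the shared core: compound 4

The compounds below may be only part of what the source reports. "The series", "measured", "known", "first", "only" and "open" are said of these compounds alone.

Measured compounds:
compound 1 `O=S(=O)(Nc1ccc(-c2nc3cc(NS(=O)(=O)c4ccc(Cl)s4)ccc3o2)cc1)c1ccc(Cl)c(C(F)(F)F)c1` 6700 nM
compound 2 `COc1ccc(S(=O)(=O)Nc2ccc3oc(-c4ccc(NC(=O)c5cccc(C)c5[N+](=O)[O-])cc4)nc3c2)cc1` 72000 nM
compound 3 `COc1ccc(S(=O)(=O)Nc2ccc3oc(-c4ccc(NC(=O)c5ccc(Cl)s5)cc4)nc3c2)cc1` 61000 nM

In an assay on mitochondria for inhibition of HSP60/HSP10 (Homo sapiens) (a higher number here means a weaker inhibitor, a lower number a stronger inhibitor), compound 3 stands second highest of the three numbers. Its nearest neighbour is compound 2, which in this assay gives 72000 nM; the step of a 1.2-fold lower number from compound 2 to compound 3 (0.07 log units; within the scatter) is within the scatter. Among the measured compounds shown here, compound 1 lies furthest away, a number that is beyond the scatter lower than that of compound 3, but compound 1 differs from compound 3 in two places, so no single step is drawn between them.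

Compound 4 `COc1ccc(S(=O)(=O)Nc2ccc3oc(-c4ccc(NS(=O)(=O)c5cc(Br)ccc5OC)cc4)nc3c2)cc1` is not yet measured. It differs from compound 3 in one place: (5-bromo-2-methoxyphenyl)sulfonyl in place of (5-chlorothiophen-2-yl)carbonyl on a nitrogen on an aromatic ring. For the measured compounds named here, no measured step covers a carbonyl replaced by a sulfonyl on this nitrogen. Going by the values given here, the one step that bears on the carbonyl side, a 1.2-fold lower number from compound 2 to compound 3 (0.07 log units; within the scatter), shows that exchanging the group on that carbonyl carbon moved the number little. Compound 1, which carries a sulfonyl on the same nitrogen, gives 6700 nM, lower than compound 3, yet its other sulfonamide is also different, so this is only a hint. On that hint a modest move toward a lower number is expected for compound 4, as a 2.0-fold lower number from compound 3 to compound 4 (0.31 log units; beyond the scatter), with a wide range: compound 4 is estimated at 30000 nM, between 8000 nM and 110000 nM.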

Compound 4, half-maximal inhibitory concentration: 67000 nM
Estimate against measurement, compound 4: 2.2-fold (0.35 log units) below, within the range that was stated.
By their numbers in this assay, from the lowest: compound 1; then compounds 3, 4 and 2 (each within the scatter of the next).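

In this assay, the (5-bromo-2-methoxyphenyl)sulfonyl on the nitrogen gives a reading that cannot be told apart from that with either carbonyl group: a 1.1-fold higher number from compound 3 to compound 4 (0.04 log units; within the scatter) against the (5-chlorothiophen-2-yl)carbonyl, and a 1.1-fold lower number from compound 2 to compound 4 (0.03 log units; within the scatter) against the (3-methyl-2-nitrophenyl)carbonyl. The earlier step had shown only that the group on the carbonyl carbon could be exchanged without a change beyond the scatter; compounds 2, 3 and 4 now show that, on this shared core, the same holds when the carbonyl itself gives way to a sulfonyl carrying a larger six-membered aromatic ring. No data at hand offer an explanation for this flat reading.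

Compound 4 differs in two places from compound 1, which gives 6700 nM, so the compounds shown do not settle which of these places, if either, goes with that value. They also leave open how the number responds at this nitrogen to a group without an aromatic ring, such as a short alkyl chain on the sulfonyl, or to a plain amine there.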